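The source may report more compounds than this note shows. Statements on the series, on what has been measured and on what is new or still open speak of the compounds shown alone.

Compound 2 `Cc1ccc(S(=O)(=O)N[C@@H](CC(=O)NC(C)(C)C)C(=O)NCCNC(=O)c2c(O)cccc2F)cc1` carries a 2-fluoro-6-hydroxyphenyl on a carbonyl carbon, and it is the starting point of the step followed here. In an ADME assay on Karpas-1106P cells (Homo sapiens) for cytotoxicity (on this read-out higher numbers stand for an effect only at larger amounts of compound and lower numbers for an effect already at smaller amounts), compound 2 gives > 11100 nM, which is a limit of the assay and not a number. Compound 1 `Cc1ccc(S(=O)(=O)N[C@@H](CC(=O)NC(C)(C)C)C(=O)NCCNC(=O)c2cccc(C(C)C)c2)cc1` is measured in this assay at > 11100 nM, again a limit. Compound 3 `Cc1ccc(S(=O)(=O)N[C@@H](CC(=O)NC(C)(C)C)C(=O)NCCNC(=O)c2cccc(C#N)c2)cc1` in this assay also returns only the limit > 11100 nM. Among the compounds with values here, all three values stand at the limit of > 11100 nM in this assay, at which 3 of the 3 values shown sit, so none of the measured steps can be read in size: a step that the two limits leave unreadable from compound 1 to compound 2, a step that the two limits leave unreadable from compound 1 to compound 3 and a step that the two limits leave unreadable from compound 2 to compound 3. Compound 4 `Cc1ccc(S(=O)(=O)N[C@@H](CC(=O)NC(C)(C)C)C(=O)NCCNC(=O)c2cccc(C(F)(F)F)c2)cc1` has not yet been measured; it differs from compound 2 as follows: 3-(trifluoromethyl)phenyl in place of 2-fluoro-6-hydroxyphenyl on a carbonyl carbon. The two steps that bear most on this change, those that likewise exchange the group on a carbonyl carbon, leave no readable size, and the third step behaves the same way. With every measured compound at the limit, no direction can be expected beyond the scatter, and compound 4 is expected to sit at the limit as well. Compound 4 is therefore estimated at 11100 nM, with a range from 5000 nM to 30000 nM. The step from compound 2 to compound 4 implied by this estimate, a number no higher from compound 2 to compound 4 (the limit leaves the size open), is expected to stay within the scatter.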

Compound 4, half-maximal effective concentration: > 11100 nM
Compound 4 gave a limit, no number; the forecaster's own chance of this, stated with the estimate: 85%; the middle value lies on the limit itself.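

Compound 4 gives only a limit in this assay, as do compound 1, compound 2 and compound 3, so none of the new steps to compound 4 can be read in size: the limit of > 11100 nM in this assay, at which 4 of the 4 values shown sit. The compounds shown leave open how the groups on the carbonyl carbon rank in this assay, and at what concentration any of them would show an effect.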